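Working notes: step from compound 2 to compound 3

The source may report more compounds than this note shows. Statements on the series, on what has been measured and on what is new or still open speak of the compounds shown alone.

Compound 2 `CC(C)c1ccccc1OS(=O)(=O)c1ccc(NC(=O)NCCCCl)cc1` stands at the lower of the two numbers measured in a functional assay on HT-1080 cells (Homo sapiens) for antiproliferative activity, read by sulforhodamine B assay, with a stated time of 48 h (on this read-out lower numbers stand for stronger inhibition and higher numbers for weaker inhibition), where compound 2 gives 2700 nM; compound 1 `CCCCCC(=O)Nc1ccc(S(=O)(=O)Oc2ccccc2C(C)C)cc1` gives 6300 nM, and the step of a 2.3-fold lower number from compound 1 to compound 2 (0.37 log units; beyond the scatter) separates them. Compound 3 `CC(C)c1ccccc1OS(=O)(=O)c1ccc(NC(=O)NCC2CCCC2)cc1` differs from compound 2 by cyclopentyl in place of 2-chloroethyl on a saturated chain carbon bound to an amide-type nitrogen. Among the measured compounds shown here, the single measured step alters a different part of the molecule, so nothing measured bears directly on this exchange. For compound 3 the expected step is therefore small, a 1.1-fold lower number from compound 2 to compound 3 (0.03 log units; within the scatter), with no firm direction. Compound 3 is estimated at 2500 nM, within a range of 900 nM to 7000 nM.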

Compound 3, half-maximal inhibitory concentration: 6000 nM
Compound 3: the middle estimate sits 2.4-fold (0.38 log units) below what was measured; the range from low to high includes it.
By their numbers in this assay, from the lowest: compound 2; then compounds 3 and 1 (each within the scatter of the next).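

At this position on a saturated chain carbon bound to an amide-type nitrogen, the group does affect the read-out in this assay: cyclopentyl in place of 2-chloroethyl gives a 2.2-fold higher number from compound 2 to compound 3 (0.35 log units; beyond the scatter). Exchanging pentyl on a carbonyl carbon for (cyclopentylmethyl)amino gives a 1.1-fold lower number from compound 1 to compound 3 (0.02 log units; within the scatter), so the lower number of compound 2 does not extend to this second amino group. Nothing available gives a reason for the step.

From the compounds shown here alone, whether the chlorine or the open chain matters remains open. A propyl or 3-hydroxypropyl group on the same nitrogen would separate these two features.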